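The source may report more compounds than this note shows. Statements on the series, on what has been measured and on what is new or still open speak of the compounds shown alone.

Measured so far in a functional assay on HEK293 cells for positive allosteric modulation of metabotropic glutamate receptor 5 (Homo sapiens), read by calcium flux; a higher number here means a larger maximal response, a lower number a smaller maximal response:
compound 1 `O=C1c2cc(COc3ccccc3)nn2CCN1c1ccc(F)cn1` gives 72%
compound 2 `Cc1ccc(N2CCn3nc(COc4ccccc4)cc3C2=O)nc1` gives 76%
compound 3 `O=C1c2cc(COc3ccc(F)cc3)nn2CCN1c1ccc(F)cc1` gives 72%

Compound 2 differs from compound 1 by methyl in place of fluoro on an aromatic carbon and the step is a number 4 percentage points higher from compound 1 to compound 2 (within the scatter). In this assay compound 3 stands level with compound 1 at the digits reported, the two together being the lowest of the three numbers, and the gap to compound 2 lies within the scatter, so no order is read into it. The difference between the core of compound 3 and the core of compound 1 is not broken down here.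

Compound 4 `Cc1ccc(OCc2cc3n(n2)CCN(c2ccc(F)cc2)C3=O)cc1` has not been measured. It differs from compound 3 by methyl in place of fluoro on an aromatic carbon. The surroundings of the place are not identical: from compound 1 to compound 2 the carbon sits on a six-membered aromatic ring with 1 nitrogen, two atoms from the ring nitrogen, while from compound 3 to compound 4 it sits on a six-membered aromatic ring of carbon only. This is the same kind of change, not the same change.

A step of about a number 2 percentage points higher from compound 3 to compound 4 (within the scatter) is expected, resting on the step of a number 4 percentage points higher from compound 1 to compound 2 (within the scatter), which stayed within the scatter. Compound 4 is therefore expected to give 74% in this assay, with a range from 62% to 86%.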

Compound 4, largest response reached (Emax), in percent of the reference or control that the assay uses: 58%
Estimate against measurement, compound 4: 16 percentage points above; the measured number lies below the stated range.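

In this assay, methyl in place of fluoro on the ring of the phenoxy group, the change from 4-fluorophenoxy to 4-methylphenoxy, gives a number 14 percentage points lower from compound 3 to compound 4 (beyond the scatter). The same kind of change therefore does not carry over at a fixed size from one core to the other: the same change on two cores in this assay, a number 4 percentage points higher (within the scatter) from compound 1 to compound 2 and a number 14 percentage points lower (beyond the scatter) from compound 3 to compound 4, 18 percentage points apart, beyond the scatter of two such steps This rests on two pairs only, and the ring bearing the change also differs between them, six-membered aromatic with 1 nitrogen in one and of carbon only in the other, so the result does not show whether that ring, the rest of the core or both set the difference, nor what the change would do on any further core.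

Still open, on these data alone, is what the same change does on the 4-fluorophenyl group that compound 3 and compound 4 share. The compounds shown also leave open how chloro, methoxy or a nitrile at the place of the fluoro on the phenoxy ring would compare with fluoro and methyl.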